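Swapping Methyl for Isopropyl and Cell Toxicity

The source may report more compounds than this note shows. Statements on the series, on what has been measured and on what is new or still open speak of the compounds shown alone.

Four close relatives from one chemical series are compared in an ADME assay on Vero cells (Chlorocebus sabaeus) for cytotoxicity; on this read-out lower numbers stand for higher toxicity in this test and higher numbers for lower toxicity in this test. For the measured compounds named here, compound 1 `CC(=O)c1c(Nc2ccc(F)cc2F)[nH]c2c(C(F)(F)F)cc(Cl)cc2c1=O` carries an acetyl group on its core and in this assay gives 7300 nM, the only plain number among the three results obtained so far. Compound 2 `CC(=O)c1c(Nc2ccc(F)cc2F)[nH]c2c(F)cc(F)cc2c1=O` shares the acetyl group but sits on a different core; how its core differs from the core of compound 1 is not broken down here. In this assay compound 2 reaches only the limit of the test, > 25000 nM. Compound 3 `CC(C)C(=O)c1c(Nc2ccc(F)cc2F)[nH]c2c(F)cc(F)cc2c1=O` is compound 2 with isopropyl in place of methyl on a carbonyl carbon. In this assay compound 3 likewise stops at the limit, > 25000 nM. The step that the two limits leave unreadable from compound 2 to compound 3 therefore cannot be read, since both of its ends rest at the limit of > 25000 nM in this assay, at which 2 of the 3 values shown sit.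

Compound 4 `CC(C)C(=O)c1c(Nc2ccc(F)cc2F)[nH]c2c(C(F)(F)F)cc(Cl)cc2c1=O` has not yet been measured. It is compound 1 with the same change, (isopropyl in place of methyl on a carbonyl carbon), made at an identical place. Going by the values given here, the one measured example of this change gives no readable size, so the expectation for compound 4 leans on the value of compound 1, 7300 nM, and on the small, carbon-only nature of what enters. The step of a 1.2-fold higher number from compound 1 to compound 4 (0.09 log units; within the scatter) is expected. In this assay compound 4 is therefore expected to give about 9000 nM, most probably between 3500 nM and 25000 nM.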

Compound 4, half-maximal cytotoxic concentration: 7300 nM
Beside the measured number, compound 4's estimate is 1.2-fold (0.09 log units) above it; measured number inside the range.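

Isopropyl in place of methyl on a carbonyl carbon gives, in this assay, no change at the digits printed from compound 1 to compound 4 (within the scatter), so on this one core the larger carbon group leaves the read-out where it was. The same change on the other core cannot be read, since compound 2 and compound 3 each stop at a limit of the test and neither gives a plain number: the limit of > 25000 nM in this assay, at which 2 of the 4 values shown sit. This series therefore offers a single readable example of the change, which shows what it does on one core but does not show that the result carries over to another, as two cores can only be compared when both steps have a readable size.

The compounds shown hold only methyl and isopropyl on this carbonyl carbon, so it stays open whether a longer chain such as butyl, or a chain ending in an amine or a carboxylic acid, would leave the read-out just as it stands. Also open, as far as these compounds go, is whether acetyl to isopropylcarbonyl would read the same on a further core that gives plain numbers at both ends of the step.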